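Chloro Repeated on a Propyl-Extended Chain

The compounds below may be only part of what the source reports. "The series", "measured", "known", "first", "only" and "open" are said of these compounds alone.

Four compounds built on one shared core are considered in a functional assay on HCT-116 cells (Homo sapiens) for antiproliferative activity, read by MTT assay, with a stated time of 48 h; on this read-out higher numbers stand for weaker inhibition and lower numbers for stronger inhibition. Compound 1 `CCCCCCC(CCO)n1cnc2c(N)ncnc21` gives in this assay > 50000 nM; this is a limit of the assay and not a number. Compound 2 `CCCCCCC(CCO)n1cnc2c(N)nc(Cl)nc21` gives > 50000 nM, again a limit rather than a number. Within the data shown here, compound 3 `CCCCCCCCCC(CCO)n1cnc2c(N)ncnc21` gives 10500 nM, the only number among the three measured values. Compound 4 `CCCCCCCCCC(CCO)n1cnc2c(N)nc(Cl)nc21` has not yet been measured.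

Compound 2 differs from compound 1 by chloro in place of hydrogen on an aromatic carbon. Since both values sit at the limit of > 50000 nM in this assay, at which 2 of the 3 values shown sit, the step that the two limits leave unreadable from compound 1 to compound 2 cannot be sized. Among the measured compounds shown here, the two cores differ by propyl in place of hydrogen on a saturated chain carbon, seven bonds along the chain from an aromatic nitrogen, and the step of an at least 4.7-fold lower number from compound 1 to compound 3 (0.67 log units; beyond the scatter) is the one readable step among the measured compounds.

Compound 4 differs from compound 3 by chloro in place of hydrogen on an aromatic carbon. For the measured compounds named here, this is the same change as the one made from compound 1 to compound 2, made now on the core of compound 3. With the earlier occurrence unreadable, there is no measured size for what this change does here. Compound 4 is therefore expected to give about 8000 nM, with the estimate lying between 2500 nM and 30000 nM. This corresponds to an expected step of a 1.3-fold lower number from compound 3 to compound 4 (0.12 log units; within the scatter), which rests on compound 3 and its value 10500 nM alone, because a step that the two limits leave unreadable from compound 1 to compound 2 gives no readable size to carry over.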

Compound 4, half-maximal inhibitory concentration: 14800 nM
Compound 4: middle estimate off by 1.9-fold (0.27 log units), on the low side; the measured number falls inside the stated range.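

In this assay, chloro in place of hydrogen on an aromatic carbon, on the propyl-extended chain, gives a 1.4-fold higher number from compound 3 to compound 4 (0.15 log units; within the scatter), so on this core the change cannot be told apart from the scatter of repeated measurements. The same change from compound 1 to compound 2 cannot be read, which leaves this as the only sized occurrence and shows neither that chloro carries over unchanged from one core to the other nor that it behaves differently on each, and the reason lies in a single limit: the limit of > 50000 nM in this assay, at which 2 of the 4 values shown sit. The propyl change, by contrast, gives an at least 3.3-fold lower number from compound 2 to compound 4 (0.52 log units; beyond the scatter), so the number falls on the chloro core as it does on the core of compound 1, but agreement in direction is all that can be said, since the sizes of the two steps cannot be compared: the same change on two cores in this assay, an at least 4.7-fold lower number (0.67 log units; beyond the scatter) from compound 1 to compound 3 and an at least 3.3-fold lower number (0.52 log units; beyond the scatter) from compound 2 to compound 4; the limit leaves it open whether they differ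

The compounds shown leave open whether a bromo or a methoxy group on that same aromatic carbon, in place of chloro, would move the number beyond the scatter. They also leave open how a longer chain, or a carboxylic acid in place of the hydroxyl, would fare on either core.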